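A few compounds are considered here, and "the series" means these few. Any claim that something is new, unique, unknown or untested is made for them only; others in the source may bear on it.

Compound 3 `O=C(CCCCCCCCn1cc(-c2cccnc2)nn1)Nc1ccccc1-c1ccccc1` gives 13% in a functional assay on SH-SY5Y cells (Homo sapiens) for cytotoxicity, tested at 1 uM (a lower number here means a stronger effect, a higher number a weaker effect of the compound at the concentration tested), the lowest of the three numbers. Its nearest neighbour, compound 2 `O=C(CCCCCCn1cc(-c2cccnc2)nn1)Nc1ccccc1-c1ccccc1`, gives 26.2% in this assay, a gap beyond the scatter, and compound 1 `N#CCCCc1cn(-c2ccncc2)nn1` gives 31%, further away still. Compound 4 `O=C(CCCCCCCCn1cc(-c2cccnc2)nn1)Nc1ccccc1Cc1ccccc1` differs from compound 3 by benzyl in place of phenyl on an aromatic carbon. Going by the values given here, no comparable change exists among the measured compounds, so the step has no precedent here. The step of a number 5 percentage points higher from compound 3 to compound 4 (within the scatter) is expected to be small, in the direction of a weaker effect, and probably not beyond the scatter. Compound 4 is therefore estimated to give 18% in this assay, with a range from 6% to 34%.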

Compound 4, a percentage reported as activity, at one concentration (the size of the read-out at that concentration, not a potency): 13.1%
Compound 4: middle estimate off by 4.9 percentage points, on the high side; the measured number falls inside the stated range.
By their numbers in this assay, from the lowest: compounds 3 and 4 (each within the scatter of the next); then compounds 2 and 1 (each within the scatter of the next).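

Benzyl in place of phenyl on this aromatic carbon, ortho to a large group, gives a number 0.1 percentage points higher from compound 3 to compound 4 (within the scatter) in this assay. Going by these compounds alone, this is the first change read at this position, and the read-out does not separate the two groups, so here the ring tolerates the extra carbon of benzyl without a visible difference. No measurement shown bears on the reason for this result.

As far as these compounds go, it remains open how phenethyl, an amine or a carboxylic acid would read on this carbon. From the compounds shown here alone, it is also open whether benzyl would read alike on the shorter chain of compound 2.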